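The source may hold more compounds than are shown below. What is called first, only, known or untested is meant among the compounds shown, and "the series" means these compounds.

Compound 1 `NC(=O)c1cc(Cl)ccc1NC(=O)COc1ccccc1`: 100000 nM
Compound 2 `NC(=O)c1cc(I)ccc1NC(=O)COc1ccccc1`: "not determined" (no result reported)

In a functional assay on OVCAR-4 cells (Homo sapiens) for inhibition (a lower number here means a stronger inhibitor of growth, a higher number a weaker inhibitor of growth), compound 1 gives 100000 nM as its result. For compound 2 the result reads "not determined" (no result reported) and gives no number, so nothing places it on the scale of this assay at all. Compound 3 is `COc1ccc(NC(=O)COc2ccccc2)c(C(N)=O)c1` and it has not yet been measured. For the measured compounds named here, the single structural change is methoxy in place of iodo on an aromatic carbon with methoxy in place of iodo on an aromatic carbon, meta to a carbamoyl group and para to a large group. Going by the values given here, no measured step shows what such a change does here. Among the compounds with values here, the only guide is compound 1 at 100000 nM so a step beyond the usual scatter is not expected, and weak growth inhibition is expected to persist. The estimate for compound 3 is 90000 nM with an expected range from 30000 nM to 150000 nM around it.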

Compound 3, concentration for 50% growth inhibition: > 100000 nM
Compound 3 was reported as a limit (the forecaster's own chance of this, stated with the estimate: 30%); middle value at least 1.1-fold (0.04 log units) from the limit.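

In this assay, compound 3 gives > 100000 nM, which is a limit of the assay and not a number. Methoxy in place of chloro on this aromatic carbon, meta to a carbamoyl group and para to a large group, gives a number no lower from compound 1 to compound 3 (the limit leaves the size open), so this change brings no gain in growth inhibition and the oxygen-linked group does no better here than chloro. The result therefore adds a second group at this position without any sign of stronger growth inhibition, and it marks the upper end of the range read so far: the limit of > 100000 nM in this assay, at which 1 of the 3 values shown sits.

As far as these compounds go, whether any group at this position can give stronger growth inhibition, for example an amine or a carboxylic acid, stays open. From the compounds shown here alone, how far compound 3 lies past its limit also stays open, and compound 2 carries no number, so iodo has no place on the scale.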